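A few compounds are considered here, and "the series" means these few. Any claim that something is new, unique, unknown or untested is made for them only; others in the source may bear on it.

In a functional assay on HCT-116 cells (Homo sapiens) for cytotoxicity, read by sulforhodamine B assay, with a stated time of 2 days (on this read-out higher numbers stand for weaker inhibition and lower numbers for stronger inhibition), compound 3 `CN(C)c1ccc(-c2nc3c(s2)C(O)CNC3)c(CO)c1` gives 100 nM, the lowest of the three numbers recorded on this shared core. Its nearest neighbour is compound 2 `OC1CNCc2nc(-c3ccc(N4CCCC4)cc3)sc21`, which in this assay gives 730 nM. Compound 1 `CN(C)c1ccc(-c2nc3c(s2)C(O)CNC3)cc1` gives 1330 nM in this assay. Two single-point steps link these measured compounds: a 13-fold lower number from compound 1 to compound 3 (1.12 log units; beyond the scatter), and a 1.8-fold lower number from compound 1 to compound 2 (0.26 log units; within the scatter).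

Compound 4 `OCc1cc(N2CCCC2)ccc1-c1nc2c(s1)C(O)CNC2` has not yet been measured in this assay. It differs from compound 3 in one place: pyrrolidin-1-yl in place of dimethylamino on an aromatic carbon. The step from compound 1 to compound 2 is the same exchange on the same aromatic carbon, only without the hydroxymethyl group, and it bears directly on the question; that step was a 1.8-fold lower number from compound 1 to compound 2 (0.26 log units; within the scatter), which stays within the scatter. The step from compound 1 to compound 3, a 13-fold lower number from compound 1 to compound 3 (1.12 log units; beyond the scatter), concerns the hydroxymethyl group and not the exchange at hand, so it does not alter the expectation for the exchange itself. Going by the values given here, there is no measured example of this exchange in the presence of the hydroxymethyl group.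

On that basis, compound 4 is expected to show no step beyond the scatter in this assay, with at most a slight lowering, a 1.4-fold lower number from compound 3 to compound 4 (0.15 log units; within the scatter). The estimate for compound 4 is therefore 70 nM, within a range of 30 nM to 200 nM.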

Compound 4, half-maximal inhibitory concentration: 70 nM
Beside the measured number, compound 4's estimate shows no gap at the digits printed, within the range that was stated.
By their numbers in this assay, from the lowest: compounds 4 and 3 (each within the scatter of the next); then compounds 2 and 1 (each within the scatter of the next).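

In this assay, the exchange of dimethylamino for pyrrolidin-1-yl now has a reading with the hydroxymethyl group present, a 1.4-fold lower number from compound 3 to compound 4 (0.15 log units; within the scatter), and it stays as small as it was without that group: the same change on two cores in this assay, a 1.8-fold lower number (0.26 log units; within the scatter) from compound 1 to compound 2 and a 1.4-fold lower number (0.15 log units; within the scatter) from compound 3 to compound 4, 1.3-fold (0.11 log units) apart, within the scatter of two such steps

The hydroxymethyl group, earlier seen only with dimethylamino on the ring, now also has a reading with pyrrolidin-1-yl, a 10-fold lower number from compound 2 to compound 4 (1.02 log units; beyond the scatter), and its large step is kept with either group: the same change on two cores in this assay, a 13-fold lower number (1.12 log units; beyond the scatter) from compound 1 to compound 3 and a 10-fold lower number (1.02 log units; beyond the scatter) from compound 2 to compound 4, 1.3-fold (0.11 log units) apart, within the scatter of two such steps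

Across these four compounds the two changes therefore read as independent of each other, with the numbers separated by the presence of the hydroxymethyl group and not by the choice between dimethylamino and pyrrolidin-1-yl.

The compounds shown leave open whether this tolerance extends to a larger or different amine in the same place, such as piperidin-1-yl, morpholin-4-yl or a plain amino group. They also leave open what the large step requires of the hydroxymethyl group, which a methyl group, a methoxymethyl group, a longer hydroxyalkyl chain or a carboxylic acid in its place would help to settle.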